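The compounds below may be only part of what the source reports. "The series", "measured", "known", "first", "only" and "open" are said of these compounds alone.

In a functional assay on MDA-MB-436 cells (Homo sapiens) for antiproliferative activity, read by MTT assay, with a stated time of 24 h (a higher number here means a weaker inhibitor, a lower number a stronger inhibitor), compound 1 `O=C(O)CC(NS(=O)(=O)c1ccccc1)c1ccccc1` gives > 100000 nM, which is a limit and not a number. Compound 2 `O=C(O)CC(NS(=O)(=O)c1ccc(F)cc1)c1ccccc1` gives > 100000 nM, also a limit. For the measured compounds named here, compound 3 `N#Cc1ccc(S(=O)(=O)NC(CC(=O)O)c2ccccc2)cc1` gives 59300 nM, the only actual number in the set. Compound 4 `O=C(O)CC(NS(=O)(=O)c1ccc(C(F)(F)F)cc1)c1ccccc1` carries trifluoromethyl in place of cyano on an aromatic carbon. Going by the values given here, three measured steps bear on this change. The first, a step that the two limits leave unreadable from compound 1 to compound 2, gives no size. The other two are an at least 1.6-fold lower number from compound 1 to compound 3 (0.22 log units; that floor lies within the scatter) and an at least 1.6-fold lower number from compound 2 to compound 3 (0.22 log units; that floor lies within the scatter), and neither shows a step beyond the scatter. The expected change is therefore small, with no direction beyond the scatter: a 1.2-fold higher number from compound 3 to compound 4 (0.07 log units; within the scatter). For compound 4 the estimated value is 70000 nM, within an expected range of 30000 nM to 100000 nM.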

Compound 4, half-maximal inhibitory concentration: 54700 nM
Estimate against measurement, compound 4: 1.3-fold (0.11 log units) above; measured number inside the range.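

In this assay, trifluoromethyl in place of cyano on the aromatic carbon gives a 1.1-fold lower number from compound 3 to compound 4 (0.04 log units; within the scatter), so the two groups cannot be told apart at this position. Trifluoromethyl in place of hydrogen gives an at least 1.8-fold lower number from compound 1 to compound 4 (0.26 log units; that floor lies within the scatter), and in place of fluoro it gives an at least 1.8-fold lower number from compound 2 to compound 4 (0.26 log units; that floor lies within the scatter), so neither floor shows a step beyond the scatter. Compound 1 and compound 2 stand at a limit and not at a number: the limit of > 100000 nM in this assay, at which 2 of the 4 values shown sit.

On these data alone, the true size of those two steps stays open. So does whether an amine or a carboxylic acid at this position would move the number beyond the scatter.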